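Aminopyrimidine rearrangement in a chromane series at the serotonin receptor

A few compounds are considered here, and "the series" means these few. Any claim that something is new, unique, unknown or untested is made for them only; others in the source may bear on it.

Measured compounds:
compound 1 `COc1cccc2c1OC(CNCCCNC1=NCCCN1)CC2` — 0.794 nM
compound 2 `Fc1ccc2c(c1)CCC(CNCCCNC1=NCCCN1)O2` — 7.94 nM
compound 3 `c1cnc(NCCCNCC2CCc3ccccc3O2)nc1` — 1.59 nM

In an assay on isolated protein (Bos taurus) with 5-hydroxytryptamine receptor 1D (Homo sapiens) as the target (a lower number here means a stronger inhibitor, a higher number a weaker inhibitor), compound 3 sits second highest of the three numbers. Compound 1 gives 0.794 nM, a gap within the scatter; compound 2 gives 7.94 nM, a gap beyond it. Compound 4 `c1ccc2c(c1)CCC(CNCCCNc1ccncn1)O2` keeps the same atoms joined differently: pyrimidin-4-yl in place of pyrimidin-2-yl on an amine nitrogen. Among the compounds with values here, no measured pair shows this change, so the step is open. The amine-bearing aromatic ring is retained with its acceptor count unchanged; a modest weakening, at the edge of the scatter, is expected from compound 3 to compound 4 a 3.1-fold higher number from compound 3 to compound 4 (0.50 log units; beyond the scatter). Compound 4 is estimated at 5 nM, in the range 1.5 nM to 20 nM.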

Compound 4, half-maximal inhibitory concentration: 10 nM
The estimate for compound 4 lay 2.0-fold (0.30 log units) below the measured number; the range from low to high includes it.
By their numbers in this assay, from the lowest: compounds 1 and 3 (each within the scatter of the next); then compounds 2 and 4 (each within the scatter of the next).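

In this assay, within the data shown here, the change from pyrimidin-2-yl to pyrimidin-4-yl on the amine nitrogen gives a 6.3-fold higher number from compound 3 to compound 4 (0.80 log units; beyond the scatter) and is the first step that can be read from a single change. The number at this position therefore depends on how the ring is joined, even though the counted heavy atoms, donors and acceptors of the group stay the same. Nothing available explains this step.

From the compounds shown here alone, whether the step holds on a core carrying methoxy or fluoro remains open. So does how a pyridin-2-yl or phenyl group on the same nitrogen would compare.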